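Methyl on the imidazole ring of an alkyne-linked carbamate

A few compounds are considered here, and "the series" means these few. Any claim that something is new, unique, unknown or untested is made for them only; others in the source may bear on it.

In a functional assay on the whole organism for agonist activity, with Mus musculus as the target (a higher number here means that more compound is needed for the effect, a lower number that less compound is needed), compound 1, `CC(C#CCn1ccnc1)N1CCCC1=O`, gives only a limit of the assay, > 100 mg/kg. Compound 2, `Cc1cncn1CC#CC(C)N1CCCC1=O`, likewise gives only a limit in this assay, > 100 mg/kg. Compound 2 differs from compound 1 by methyl in place of hydrogen on an aromatic carbon, and the resulting step that the two limits leave unreadable from compound 1 to compound 2 cannot be read from two limits. Compound 3, `CCOC(=O)N(C)C(C)C#CCn1ccnc1`, also stands at a limit in this assay, > 100 mg/kg. How the core of compound 3 differs from the core of compound 1 is not broken down here. Compound 4, `CCOC(=O)N(C)C(C)C#CCn1cncc1C`, has not yet been measured in this assay; it differs from compound 3 by methyl in place of hydrogen on an aromatic carbon, which is the same change that was made from compound 1 to compound 2. The evidence on the measured pair rests on (the limit of > 100 mg/kg in this assay, at which 3 of the 3 values shown sit), and that limit is all the three values show. Because compound 3 sits at a limit, > 100 mg/kg, as compound 1 does, > 100 mg/kg, and because the same change left compound 2 at a limit, > 100 mg/kg, the step from compound 3 to compound 4 is expected to be a step that the limit leaves unreadable from compound 3 to compound 4, with a high chance that only a limit is reported again. For compound 4 the estimated value in this assay is 200 mg/kg, expected between 100 mg/kg and 1000 mg/kg.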

Compound 4, dose for half-maximal effect: > 100 mg/kg
Compound 4: a limit, no number; the forecaster's own chance of this, stated with the estimate: 85%; the middle value lies beyond the limit too.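

In this assay compound 4 stands at the limit > 100 mg/kg and gives no number. Compound 3 also stands at a limit, so no step can be read between compound 3 and compound 4, and all the values shown sit at one limit: the limit of > 100 mg/kg in this assay, at which 4 of the 4 values shown sit.

The compounds shown leave open whether methyl in place of hydrogen on an aromatic carbon changes the dose needed for the effect in this assay at all.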